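Notes on compound 4 and its measured neighbours

The source may hold more compounds than are shown below. What is called first, only, known or untested is meant among the compounds shown, and "the series" means these compounds.

Measured in a functional assay on MGC-803 cells (Homo sapiens) for inhibition, read by MTT assay, with a stated time of 72 h; a higher number here means a weaker inhibitor, a lower number a stronger inhibitor:
compound 1 `Cc1cc(N2CC[C@@H](C)[C@@H](N(C)c3ncnc4[nH]ccc34)C2)n2nc(SCc3csc4ccc(Cl)cc34)nc2n1`: > 100000 nM, a limit of the assay
compound 2 `Cc1cc(N2CC[C@@H](C)[C@@H](N(C)c3ncnc4[nH]ccc34)C2)n2nc(SCc3ccc(F)c(Cl)c3)nc2n1`: 52000 nM
compound 3 `Cc1cc(N2CC[C@@H](C)[C@@H](N(C)c3ncnc4[nH]ccc34)C2)n2nc(SCc3ccc(Br)cc3)nc2n1`: 4020 nM

Compound 1 stands at the edge of the numbers: the value given above is a limit of the assay and not a measured number (the limit of > 100000 nM in this assay, at which 1 of the 3 values shown sits). Its place relative to compound 2 is open, since an at least 1.9-fold lower number from compound 1 to compound 2 (0.28 log units; that floor lies within the scatter). Against compound 3 the gap is clear: an at least 24-fold lower number from compound 1 to compound 3 (1.39 log units; beyond the scatter). Between the two phenyl analogues the ordering is also clear, with a 13-fold lower number from compound 2 to compound 3 (1.11 log units; beyond the scatter).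

Compound 4 `Cc1cc(N2CC[C@@H](C)[C@@H](N(C)c3ncnc4[nH]ccc34)C2)n2nc(SCc3ccc(C(F)(F)F)cc3)nc2n1` is the next member. It differs from compound 1 by 4-(trifluoromethyl)phenyl in place of 5-chloro-1-benzothiophen-3-yl on a saturated chain carbon bound to a sulfur. Among the compounds with values here, the steps that bear on it are both from compound 1: an at least 1.9-fold lower number from compound 1 to compound 2 (0.28 log units; that floor lies within the scatter) and an at least 24-fold lower number from compound 1 to compound 3 (1.39 log units; beyond the scatter). The closer precedent is compound 3, which likewise carries a single six-membered carbon ring with one substituent at the 4-position, and that step was large. A step of similar kind and direction is therefore expected for compound 4, namely an at least 20-fold lower number from compound 1 to compound 4 (1.30 log units; beyond the scatter), with the understanding that the starting point is only a limit.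

Compound 4 is accordingly expected to give 5000 nM in this assay, estimated within 1500 nM to 20000 nM.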

Compound 4, half-maximal inhibitory concentration: 2680 nM
Estimate against measurement, compound 4: 1.9-fold (0.27 log units) above; low and high end bracket the measured number.
By their numbers in this assay, from the lowest: compounds 4 and 3 (each within the scatter of the next); then compound 2. At a limit, above all of these: compound 1.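

In this assay compound 1 gives > 100000 nM, which is a limit of the assay and not a measured number: the limit of > 100000 nM in this assay, at which 1 of the 4 values shown sits.

Even so, the floor of the new step clears the scatter, an at least 37-fold lower number from compound 1 to compound 4 (1.57 log units; beyond the scatter), and the step from the disubstituted phenyl is also large, a 19-fold lower number from compound 2 to compound 4 (1.29 log units; beyond the scatter), so compound 4 joins compound 3 well apart from compound 2 on this saturated chain carbon bound to a sulfur. Within the data shown here, what the earlier compounds did not show is that the bromo group of compound 3 can be exchanged for trifluoromethyl on the aromatic carbon with no separation beyond the scatter, a 1.5-fold lower number from compound 3 to compound 4 (0.18 log units; within the scatter), so among the four compounds 4-bromophenyl and 4-(trifluoromethyl)phenyl give values that cannot be told apart.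

From the compounds shown here alone, how far the 5-chloro-1-benzothiophen-3-yl group of compound 1 really lies from the others stays open, since every step from compound 1 is only a floor. Also open, going by these compounds, is whether the values of compound 3 and compound 4 would hold with an amine or a carboxylic acid on the phenyl ring in place of bromo or trifluoromethyl, or with a longer chain between the sulfur and the ring.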